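The source may hold more compounds than are shown below. What is called first, only, known or untested is meant among the compounds shown, and "the series" means these compounds.

In a functional assay on K562 cells (Homo sapiens) for inhibition, read by CCK-8 assay, with a stated time of 72 h (on this read-out lower numbers stand for stronger inhibition and higher numbers for weaker inhibition), compound 1 `O=C(/C=C/c1cccnc1)NCCCCCc1cccc(S(=O)(=O)Nc2ccccc2)c1` gives 16.3 nM and compound 2 `Cc1ccc(NS(=O)(=O)c2cccc(CCCCCCNC(=O)/C=C/c3cccnc3)c2)cc1` gives 2.98 nM, the lower number of the two, with a gap beyond the scatter. The next structure, compound 3 `CC(C)(C)c1ccc(NS(=O)(=O)c2cccc(CCCCCCNC(=O)/C=C/c3cccnc3)c2)cc1`, carries tert-butyl in place of methyl on an aromatic carbon. For the measured compounds named here, no measured step in this assay covers this change, so only a small weakening is expected, possibly none beyond the scatter. The estimated change is a 1.7-fold higher number from compound 2 to compound 3 (0.22 log units; within the scatter). For compound 3 the expected value is 5 nM, with an estimated range of 1.5 nM to 16 nM.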

Compound 3, half-maximal inhibitory concentration: 24.7 nM
Beside the measured number, compound 3's estimate is 4.9-fold (0.69 log units) below it; measured number outside the range, above it.
By their numbers in this assay, from the lowest: compound 2; then compounds 1 and 3 (each within the scatter of the next).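

For the compounds shown here, at this place, para to a large group, the exchange of 4-methylphenyl for 4-(tert-butyl)phenyl gives an 8.3-fold higher number from compound 2 to compound 3 (0.92 log units; beyond the scatter), the first measured step at this position. It shows that the position does not accept this change without loss, although the change goes from one heavy atom to four and adds no hydrogen-bond donor, acceptor or net charge. No measurement shown here accounts for the loss. The compounds shown leave open how ethyl or isopropyl would read at this position, and whether an amine or a methoxy group would keep the number of compound 2.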